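Bromo in place of nitrooxy on a bis-benzylidene piperidinone

The source may report more compounds than this note shows. Statements on the series, on what has been measured and on what is new or still open speak of the compounds shown alone.

Compound 1, `O=C1/C(=C/c2ccccc2F)CN(S(=O)(=O)c2ccc(O[N+](=O)[O-])cc2)C/C1=C\c1ccccc1F`, 16500 nM
Compound 2, `O=C1/C(=C/c2ccc(F)cc2)CN(S(=O)(=O)c2ccc(O[N+](=O)[O-])cc2)C/C1=C\c1ccc(F)cc1`, 5400 nM

Of the compounds shown here, two have been measured in a functional assay on HepG2 cells (Homo sapiens) for cytotoxicity, read by MTT assay, with a stated time of 24 h; on this read-out lower numbers stand for stronger inhibition and higher numbers for weaker inhibition. Compound 2 gives 5400 nM, the lower of the two numbers, and compound 1 gives 16500 nM, a higher number that lies beyond the usual scatter of this assay. The next compound, compound 3, `O=C1/C(=C/c2ccc(F)cc2)CN(S(=O)(=O)c2ccc(Br)cc2)C/C1=C\c1ccc(F)cc1`, keeps the core of compound 2 and changes only the sulfonyl-bound aryl ring: bromo in place of nitrooxy on an aromatic carbon. Among the measured compounds shown here, no measured pair shows this change, so its effect is unknown. The step from the fluorine shift between compound 1 and compound 2 does not bear on it. Compound 3 is therefore expected to stay near compound 2, with a step of a 1.5-fold higher number from compound 2 to compound 3 (0.17 log units; within the scatter) that could lie within the scatter or slightly toward a higher number. The estimate for compound 3 in this assay is 8000 nM, with a range from 2500 nM to 25000 nM.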

Compound 3, half-maximal inhibitory concentration: 8000 nM
Estimate against measurement, compound 3: no gap at the digits printed, within the range that was stated.
By their numbers in this assay, from the lowest: compounds 2 and 3 (each within the scatter of the next); then compound 1.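

Compound 1 and compound 2 both carry the 4-(nitrooxy)phenyl group, so neither could speak to this position, whereas in this assay the change to 4-bromophenyl gives a 1.5-fold higher number from compound 2 to compound 3 (0.17 log units; within the scatter) and provides the first reading there. At this aromatic carbon, para to a large group, the nitrooxy group can therefore be replaced by a single bromine atom without a shift beyond the scatter, at least on the core of compound 2. Nothing at hand accounts for this result or tells how either group acts in the cells.

Bromo appears here only with the fluorine placement of compound 2, so it remains open whether the same swap would read alike with the fluorine placement of compound 1. Also open, as far as these compounds go, is how an amine or a carboxylic acid on this aromatic carbon would read in this assay against these two groups.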